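A Shorter Group on the Nitrogen of Compound 2

A few compounds are considered here, and "the series" means these few. Any claim that something is new, unique, unknown or untested is made for them only; others in the source may bear on it.

Values measured in a functional assay (aorta) for inhibition, with Rattus norvegicus as the target; on this read-out higher numbers stand for weaker inhibition and lower numbers for stronger inhibition
Compound 1 (`CCC/N=C(\S)[C@]1(c2cccnc2)CCCC[S+]1[O-]`) gives 600 nM
Compound 2 (`CCCC/N=C(\S)[C@]1(c2cccnc2)CCCC[S+]1[O-]`) gives 8000 nM

Among the compounds with values here, of the two numbers so far, compound 2 holds the highest (8000 nM). Its nearest neighbour on this scale is compound 1 (600 nM). The next structure, compound 3 (`N/N=C(\S)[C@]1(c2cccnc2)CCCC[S+]1[O-]`), carries amino in place of butyl on a double-bonded nitrogen. Within the data shown here, only one measured step bears on this change, and only indirectly. It is the large step of a 13-fold higher number from compound 1 to compound 2 (1.12 log units; beyond the scatter), which came with methyl in place of hydrogen on a saturated chain carbon and lies beyond the scatter. Among the measured compounds shown here, no measured compound carries amino at this place, so the transfer is uncertain, but removing the butyl chain points towards a lower number. The expected change is a 13-fold lower number from compound 2 to compound 3 (1.12 log units; beyond the scatter), a sizeable step downward in this assay. For compound 3 the estimated value is 600 nM, with an expected range from 80 nM to 4500 nM.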

Compound 3, concentration for 90% inhibition: > 30000 nM
Compound 3: a limit, no number (the forecaster's own chance of this, stated with the estimate: 5%); middle value at least 50-fold (1.69 log units) from the limit.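

Compound 3 gives no number but a limit in this assay: the limit of > 30000 nM in this assay, at which 1 of the 3 values shown sits. Shortening the group on the double-bonded nitrogen therefore does not simply lower the number, as amino in place of butyl brings an at least 3.7-fold higher number from compound 2 to compound 3 (0.57 log units; beyond the scatter), and amino in place of propyl brings an at least 50-fold higher number from compound 1 to compound 3 (1.69 log units; beyond the scatter). Among these three compounds the number is lowest with propyl, and both compound 2 and compound 3 lie higher, so no trend in one direction holds at this place.

From the compounds shown here alone, how far compound 3 lies past its limit stays open, so both new steps are bounded on one side only. The compounds shown also do not tell whether methyl, ethyl or a branched chain such as isopropyl on this nitrogen would match propyl, or whether the result with amino comes from the added nitrogen or from the lost carbon chain.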